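The compounds below may be only part of what the source reports. "The series", "measured", "known", "first", "only" and "open" are said of these compounds alone.

Measured so far in a functional assay on HCC 2998 cells (Homo sapiens) for cytotoxicity, read by sulforhodamine B assay, with a stated time of 48 h; on this read-out higher numbers stand for weaker inhibition of growth and lower numbers for stronger inhibition of growth:
compound 1 `ClCc1ccccc1Cn1cnc2c(Cl)ncnc21` gives 1660 nM
compound 2 `ClCc1ccc(Cn2cnc3ncnc(Cl)c32)cc1` gives 1410 nM

Compound 2 gives 1410 nM in this assay, and the value of compound 1 lies within the usual scatter of it, so the two compounds cannot be told apart on these numbers. Compound 3 `ClCc1ccc(Cn2cnc3nc(Cl)nc(Cl)c32)cc1` has not yet been measured. It differs from compound 2 in one place: chloro in place of hydrogen on an aromatic carbon. Among the measured compounds shown here, no measured pair shows what this change does here, so nothing firm can be drawn from the data. The expected step is a 1.2-fold lower number from compound 2 to compound 3 (0.07 log units; within the scatter), small and within the scatter. Compound 3 is therefore estimated at about 1200 nM, within a range from 500 nM to 3000 nM.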

Compound 3, concentration for 50% growth inhibition: 2040 nM
Estimate against measurement, compound 3: 1.7-fold (0.23 log units) below; low and high end bracket the measured number.
By their numbers in this assay, from the lowest: compounds 2, 1 and 3 (each within the scatter of the next).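

Chloro in place of hydrogen on the aromatic carbon between two ring nitrogen atoms gives a 1.4-fold higher number from compound 2 to compound 3 (0.16 log units; within the scatter) in this assay and this is the first reading of this change. A chloro group is therefore tolerated at this position, with no difference that these numbers can separate from the scatter of repeated measurements. No available evidence bears on why this is so. As far as these compounds go, whether an amine or a methoxy group at this position would also leave the number within the scatter remains open.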